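Aryl variation on the ring nitrogen of compound 1

The source may hold more compounds than are shown below. What is called first, only, known or untested is meant among the compounds shown, and "the series" means these compounds.

Compound 1 `COc1ccc(F)cc1N1C(=O)CSC1c1cccc(C(=O)NCCCCc2ccccc2)c1` gives 76% in a functional assay on SJSA-1 cells (Homo sapiens) for inhibition, read by CCK-8 assay, with a stated time of 72 h, tested at 1 uM (a lower number here means less inhibition, a higher number more inhibition at the concentration tested (going by the name of the read-out)), the higher of the two numbers in hand. Compound 2 `COc1c(F)cccc1N1C(=O)CSC1c1cccc(C(=O)NCCCCc2ccccc2)c1` gives 1% in this assay. Among the measured compounds shown here, the single measured step, a number 75 percentage points lower from compound 1 to compound 2 (beyond the scatter), shows that the aryl group on the ring nitrogen governs the read-out. Compound 3 `COc1ccc(N2C(=O)CSC2c2cccc(C(=O)NCCCCc3ccccc3)c2)c(OC)c1` differs from compound 1 by 2,4-dimethoxyphenyl in place of 5-fluoro-2-methoxyphenyl on an amide-type nitrogen in a ring. For the measured compounds named here, no measured step covers this exact change; the step from compound 1 to compound 2 only shows that another aryl pattern can abolish inhibition. The step of a number 36 percentage points lower from compound 1 to compound 3 (beyond the scatter) is expected to be a loss of uncertain size. Compound 3 is estimated at 40%, with a range of 5% to 80%.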

Compound 3, a percentage reported as inhibition, at one concentration (the size of the read-out at that concentration, not a potency): 85%
Estimate against measurement, compound 3: 45 percentage points below; measured number above the stated range.
By their numbers in this assay, from the lowest: compound 2; then compounds 1 and 3 (each within the scatter of the next).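

In this assay, 2,4-dimethoxyphenyl on the amide-type nitrogen gives a number 9 percentage points higher from compound 1 to compound 3 (within the scatter), so fluorine is not required on this aryl group for the read-out to stay high. Against 3-fluoro-2-methoxyphenyl, the same group gives a number 84 percentage points higher from compound 2 to compound 3 (beyond the scatter), so the collapse belongs to that one aryl pattern and not to every change at this position. Nothing at hand explains these differences.

Still open, going by these compounds, is whether plain phenyl holds the inhibition, and how this aryl group reads with a nitrile or a carboxylic acid in place of a methoxy group.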